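A few compounds are considered here, and "the series" means these few. Any claim that something is new, unique, unknown or untested is made for them only; others in the source may bear on it.

Measured so far:
compound 1, `CCCc1nn(C)c2c(NC(C)C)nc(-c3cc(OC)c(OC)c(OC)c3)nc12`: > 50000 nM
compound 2, `CCCc1nn(C)c2c(N3CCC(O)CC3)nc(/C=C/c3cc(OC)c(OC)c(OC)c3)nc12`: > 50000 nM

In an ADME assay on RAW264.7 cells (Mus musculus) for cytotoxicity (on this read-out higher numbers stand for weaker inhibition and lower numbers for stronger inhibition), compound 1 gives only a limit of the assay, > 50000 nM, and not a number. Compound 2, a second compound built on the shared core, also stops at a limit in this assay, > 50000 nM. The two values shown therefore sit at the same boundary: the limit of > 50000 nM in this assay, at which 2 of the 2 values shown sit. No step between measured compounds is available, so compound 1 stands nowhere in particular on the numbers shown; it is simply one of two compounds at the limit.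

Compound 3, `CCCc1nn(C)c2c(N3CCCC3)nc(-c3cc(OC)c(OC)c(OC)c3)nc12`, differs from compound 1 in one place: pyrrolidin-1-yl in place of isopropylamino on an aromatic carbon. With both measured compounds at the limit, the estimated step is a number no higher from compound 1 to compound 3 (the limit leaves the size open), none beyond the scatter. Compound 3 is therefore expected to give 50000 nM, ranging from 20000 nM to 100000 nM, and most likely again only a limit.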

Compound 3, half-maximal inhibitory concentration: > 50000 nM
Compound 3: a limit, no number; the forecaster's own chance of this, stated with the estimate: 80%; the middle value lies on the limit itself.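

No step can be read between compound 1 and compound 3 in this assay, and the values shown stand together at one boundary: the limit of > 50000 nM in this assay, at which 3 of the 3 values shown sit. The compounds shown leave open whether any change on the shared core would give a measurable number in this assay.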